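Amide substituent swaps on a stilbenoid pyridine ether series

This account rests on a few compounds, and the source may have more. Where it says the series, first, only, none or still open, it means among the compounds named here.

Measured compounds:
compound 1, `COc1ccc(CNC(=O)c2cc(Oc3ccc(/C=C/c4ccccn4)cc3)ccn2)cc1`, 26000 nM
compound 2, `CNC(=O)c1cc(Oc2ccc(/C=C/c3ccncc3)cc2)ccn1`, 18200 nM
compound 3, `COc1ccc(NC(=O)c2cc(Oc3ccc(/C=C/c4ccncc4)cc3)ccn2)cc1`, > 100000 nM

In a functional assay on HepG2 cells (Homo sapiens) for antiproliferative activity, read by CCK-8 assay, with a stated time of 48 h (on this read-out lower numbers stand for stronger inhibition and higher numbers for weaker inhibition), compound 3 returns only a limit, > 100000 nM, so its position among the three is known only as the weakest end of what was measured. Compound 2 carries a methyl on the amide-type nitrogen and gives 18200 nM in this assay. For the measured compounds named here, the one step that touches compound 3 is an at least 5.4-fold higher number from compound 2 to compound 3 (0.73 log units; beyond the scatter), and the reading of compound 3 sits at the limit of > 100000 nM in this assay, at which 1 of the 3 values shown sits.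

Compound 4, `COc1ccc(CNC(=O)c2cc(Oc3ccc(/C=C/c4ccncc4)cc3)ccn2)cc1`, has not been measured in this assay. It differs from compound 3 in one place: 4-methoxybenzyl in place of 4-methoxyphenyl on an amide-type nitrogen. Compound 1 carries that same 4-methoxybenzyl on the amide-type nitrogen, though with a different pyridine, and gives 26000 nM in this assay. Because the step of an at least 5.4-fold higher number from compound 2 to compound 3 (0.73 log units; beyond the scatter) was at least modest and ran toward a weaker value, undoing the 4-methoxyphenyl in compound 4 is expected to move back toward a finite number. For compound 4 the estimated step is an at least 3.5-fold lower number from compound 3 to compound 4 (0.55 log units; beyond the scatter), a return toward the range of compound 1. Compound 4 is therefore estimated at 28000 nM in this assay, with a likely spread from 9000 nM to 90000 nM.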

Compound 4, half-maximal inhibitory concentration: > 100000 nM
Compound 4: a limit, no number; the forecaster's own chance of this, stated with the estimate: 20%; middle value at least 3.5-fold (0.55 log units) away from the limit.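

In this assay, compound 4 returns only a limit, > 100000 nM, so 4-methoxybenzyl in place of 4-methoxyphenyl on the amide-type nitrogen does not bring back a finite number, and the steps that rest on two limits cannot be read. For the compounds shown here, with the 4-methoxybenzyl amide held fixed, the result shows that the pyridine matters, which the earlier compounds could not show: pyridin-4-yl in place of pyridin-2-yl gives an at least 3.8-fold higher number from compound 1 to compound 4 (0.58 log units; beyond the scatter). Within the pyridin-4-yl compounds, the methyl amide compound 2 remains the only one with a finite value, and moving to the 4-methoxybenzyl amide gives an at least 5.4-fold higher number from compound 2 to compound 4 (0.73 log units; beyond the scatter), though both of these steps are open-ended and rest on a shared limit: the limit of > 100000 nM in this assay, at which 2 of the 4 values shown sit.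

The compounds shown leave open whether a group without the aromatic ring on the amide-type nitrogen, such as an ethyl group, a longer chain ending in an amine, or a carboxylic acid, would keep a finite value with pyridin-4-yl. They also leave open how 4-methoxyphenyl would read with pyridin-2-yl, and how far apart compound 3 and compound 4 really lie.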